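A few compounds are considered here, and "the series" means these few. Any claim that something is new, unique, unknown or untested is made for them only; others in the source may bear on it.

Working notes on the series. Compound 2 `C=CC(=O)Nc1cc(CCCN2CCCC2)cc(C)c1Nc1ncc2cc(-c3c(Cl)c(OC)cc(OC)c3Cl)ccc2n1` gives 4260 nM in a functional assay on Huh-7 cells (Homo sapiens) for inhibition, read by sulforhodamine B assay, with a stated time of 72 h (on this read-out higher numbers stand for weaker inhibition and lower numbers for stronger inhibition), the highest of the three numbers measured. Within the data shown here, compound 1 `C=CC(=O)Nc1cc(CCCN(C)C)cc(C)c1Nc1ncc2cc(-c3c(Cl)c(OC)cc(OC)c3Cl)ccc2n1` gives 2240 nM in this assay, and the single-place step a 1.9-fold higher number from compound 1 to compound 2 (0.28 log units; within the scatter) is the only one recorded between measured compounds. Compound 3 `C=CC(=O)Nc1cc(SC)ccc1Nc1ncc2cc(-c3c(Cl)c(OC)cc(OC)c3Cl)ccc2n1` gives 936 nM in this assay; it differs from compound 2 in more than one place, so the two values can only be set side by side, with compound 3 sitting beyond the scatter on the lower side.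

Compound 4 `C=CC(=O)Nc1cc(S(N)(=O)=O)cc(C)c1Nc1ncc2cc(-c3c(Cl)c(OC)cc(OC)c3Cl)ccc2n1` carries the change (sulfamoyl in place of 3-(pyrrolidin-1-yl)propyl on an aromatic carbon). Among the measured compounds shown here, no measured step covers a swap of this kind; the one step recorded, between compound 1 and compound 2, only exchanges the amine at the end of the same chain and stays within the scatter, so it gives no direction. With nothing to anchor the size of the change, the expectation for compound 4 is kept near the parent, as the step of a 2.1-fold lower number from compound 2 to compound 4 (0.33 log units; beyond the scatter), and the number expected for compound 4 in this assay is 2000 nM, estimated to lie between 500 nM and 8000 nM.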

Compound 4, half-maximal inhibitory concentration: 1670 nM
The estimate for compound 4 lay 1.2-fold (0.08 log units) above the measured number; low and high end bracket the measured number.
By their numbers in this assay, from the lowest: compounds 3, 4, 1 and 2 (each within the scatter of the next, the first and the last beyond it).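

Replacing 3-(pyrrolidin-1-yl)propyl with sulfamoyl on this aromatic carbon gives a 2.6-fold lower number from compound 2 to compound 4 (0.41 log units; beyond the scatter) in this assay, a modest step and the first at this position to exceed the scatter, whereas the earlier step only exchanged the amine at the end of the chain. Against the 3-(dimethylamino)propyl chain, the same group gives a 1.3-fold lower number from compound 1 to compound 4 (0.13 log units; within the scatter) in this assay, so a chain ending in an amine is not needed at this carbon to keep a number of this size, and the step beyond the scatter holds only against the pyrrolidine-bearing chain. No measurement available here explains the difference between the two steps.

On these data alone, whether a carboxylic acid, a primary amine or a methyl-substituted sulfonamide on this carbon would keep the same number remains open. As far as these compounds go, what the methyl group on this ring contributes also remains open, since compound 3 differs from compound 4 in more than one place.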